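The source may report more compounds than this note shows. Statements on the series, on what has been measured and on what is new or still open speak of the compounds shown alone.

Three close relatives have been tested in a functional assay on MDA-MB-231 cells (Homo sapiens) for inhibition, read by sulforhodamine B assay, with a stated time of 72 h; on this read-out higher numbers stand for weaker inhibition of growth and lower numbers for stronger inhibition of growth. Compound 1 `CNC(=O)/C=C/c1ccncc1-c1ccc2ccccc2c1` gives 8680 nM in this assay. Compound 2 `O=C(O)/C=C/c1ccncc1-c1ccc2ccccc2c1` differs from compound 1 by hydroxy in place of methylamino on a carbonyl carbon. The value of compound 2 in this assay is a limit of the assay, > 10000 nM. That change therefore gave an at least 1.1-fold higher number from compound 1 to compound 2 (0.06 log units; that floor lies within the scatter). Compound 3 `CNC(=O)/C=C/c1ccncc1-c1ccc2[nH]ccc2c1` carries the same chain on another core; the difference between the two cores is not broken down here. The value of compound 3 in this assay is also a limit of the assay, > 10000 nM. Compound 4 `O=C(O)/C=C/c1ccncc1-c1ccc2[nH]ccc2c1`, not yet measured, is related to compound 3 by hydroxy in place of methylamino on a carbonyl carbon, the same change that turns compound 1 into compound 2, at the same place. The step is expected to be a step that the limit leaves unreadable from compound 3 to compound 4, a weakening or no measurable movement, because the limit of > 10000 nM in this assay, at which 2 of the 3 values shown sit, and the earlier step points the same way. Compound 4 is therefore estimated at 20000 nM, plausibly between 8000 nM and 60000 nM, most likely reported only as a limit.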

Compound 4, concentration for 50% growth inhibition: > 10000 nM
Compound 4: a limit, no number (the forecaster's own chance of this, stated with the estimate: 85%); the middle value lies beyond the limit too.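

Among the compounds shown here, compound 3 and compound 4 each carry a limit of the assay rather than a number, so the change from methylcarbamoyl to carboxy yields no step that can be read here. The compounds shown leave open how strongly compound 2, compound 3 and compound 4 actually inhibit growth, and whether this change moves the value at all on either core.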